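The compounds below may be only part of what the source reports. "The series", "measured", "known", "first", "only" and "open" are said of these compounds alone.

Measured in a functional assay on MCF7 cells (Homo sapiens) for antiproliferative activity, read by MTT assay; a lower number here means a stronger inhibitor, a higher number a weaker inhibitor:

- compound 1 `CCCC/C=C\CCCCCCCCCC1(O)CC(=O)c2c(O)cc(OCOC)cc2O1`: 43200 nM
- compound 2 `CC/C=C\C/C=C\C/C=C\CCCCCCCc1cc(=O)c2c(O)c(C)c(O)cc2o1`: 17500 nM
- compound 3 `CCCCC1(O)CC(=O)c2c(O)cc(O)cc2O1`: > 67200 nM, a limit and not a number

Compound 3 has no number in this assay. Among the compounds with values here, its only result is the limit > 67200 nM, and it is the one compound of the three that sits at this limit.

Compound 4 `CCCCCCCCCCCC1(O)CC(=O)c2c(O)cc(O)cc2O1` has not yet been measured. It differs from compound 3 by one change: heptyl in place of hydrogen on a saturated chain carbon, four bonds along the chain from a saturated ring carbon. The same difference can also be read as methyl to octyl.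

Within the data shown here, no measured pair isolates this change, so the expectation rests on indirect evidence. A longer chain than that of compound 3 is also carried by compound 1, which gives 43200 nM. Compound 2, a further long-chain compound on a different core, gives 17500 nM. A moderate gain in strength is therefore expected, and it may prove small. The expected change is an at least 1.9-fold lower number from compound 3 to compound 4 (0.28 log units; that floor lies within the scatter).

For compound 4 the estimated value is 35000 nM, within an expected range of 15000 nM to 70000 nM.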

Compound 4, half-maximal inhibitory concentration: 43200 nM
Beside the measured number, compound 4's estimate is 1.2-fold (0.09 log units) below it; the measured number falls inside the stated range.
By their numbers in this assay, from the lowest: compound 2; then compounds 1 and 4 (each within the scatter of the next). At a limit, above all of these: compound 3.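

In this assay, heptyl in place of hydrogen on a saturated chain carbon, four bonds along the chain from a saturated ring carbon, now has a direct reading on the shared core: an at least 1.5-fold lower number from compound 3 to compound 4 (0.19 log units; that floor lies within the scatter). Compound 3 has only a limit, > 67200 nM, and not a number, whereas compound 4 gives a measured value of 43200 nM. The step therefore gives only a floor, and its full size cannot be read, as it rests on a limit of the assay: the limit of > 67200 nM in this assay, at which 1 of the 4 values shown sits.

The compounds shown leave open whether the change truly exceeds the usual scatter and whether a longer chain would lower the number further. They also leave open how an amine or a carboxylic acid in place of the heptyl would read in this assay.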